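The compounds below may be only part of what the source reports. "The series", "measured", "known", "first", "only" and "open" are said of these compounds alone.

Compound 1 `O=C1c2c[n+]([O-])c3ccccc3c2C(=O)c2c1c1ccccc1n2Cc1cn(CC(O)CO)nn1` — > 1000 nM
Compound 2 `O=C1c2c[n+]([O-])c3ccccc3c2C(=O)c2c1c1ccccc1n2CCN1CCCC1` — 520 nM

In a functional assay on SH-SY5Y cells (Homo sapiens) for cytotoxicity, read by MTT assay, with a stated time of 72 h (a lower number here means a stronger inhibitor, a higher number a weaker inhibitor), compound 1 gives > 1000 nM, which is a limit of the assay rather than a number. That is the limit of > 1000 nM in this assay, at which 1 of the 2 values shown sits. In this assay compound 2 gives 520 nM. The step between them, an at least 1.9-fold lower number from compound 1 to compound 2 (0.28 log units; that floor lies within the scatter), is all that has been measured here, and its size cannot be read beyond its floor because compound 1 only reaches the limit (the limit of > 1000 nM in this assay, at which 1 of the 2 values shown sits).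

Compound 3 `O=C1c2c[n+]([O-])c3ccccc3c2C(=O)c2c1c1ccccc1n2Cc1cn([C@@H]2O[C@H](CO)[C@@H](O)[C@H](O)[C@H]2O)nn1` is compared with compound 1. The change is 3,4,5-trihydroxy-6-(hydroxymethyl)oxan-2-yl in place of 2,3-dihydroxypropyl on an aromatic nitrogen. Within the data shown here, no measured step alters this part of the molecule: the only measured step exchanges the whole triazole unit for a different group, so it does not bear directly on the change to compound 3. With compound 1 at the limit and no evidence for a shift from a larger sugar-like substituent on the triazole nitrogen, compound 3 is expected to remain around the same limit, so a step that the limit leaves unreadable from compound 1 to compound 3 is estimated to be no step beyond the scatter. In this assay compound 3 is therefore estimated at 2000 nM, within 800 nM to 6000 nM.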

Compound 3, half-maximal inhibitory concentration: 880 nM
Compound 3: middle estimate off by 2.3-fold (0.36 log units), on the high side; measured number inside the range.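

In this assay, compound 3 gives 880 nM, the only readable number among the compounds shown that keep the triazole, so this aromatic nitrogen can carry the much larger 3,4,5-trihydroxy-6-(hydroxymethyl)oxan-2-yl group and still yield a measured value. Exchanging 2,3-dihydroxypropyl for this group, which brings in a six-membered non-aromatic ring, gives an at least 1.1-fold lower number from compound 1 to compound 3 (0.05 log units; that floor lies within the scatter), and a floor within the scatter does not establish any real change. The true size of the step stays unknown because compound 1 has only a limit of the assay: the limit of > 1000 nM in this assay, at which 1 of the 3 values shown sits.

The exchange alters the ring, the number of hydroxyl groups and the stereocentres all at once, so the compounds shown do not separate what each of these contributes. Also open, on these data alone, is what this assay would report with a plain butyl chain, an amine or a carboxylic acid on this aromatic nitrogen, or with a sugar of different stereochemistry in place of the 3,4,5-trihydroxy-6-(hydroxymethyl)oxan-2-yl group.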